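The source may report more compounds than this note shows. Statements on the series, on what has been measured and on what is new or still open speak of the compounds shown alone.

In a functional assay on SK-BR-3 cells (Homo sapiens) for antiproliferative activity, read by MTT assay, with a stated time of 72 h (on this read-out higher numbers stand for weaker inhibition and lower numbers for stronger inhibition), compound 1, whose structure is `C/C=C1/[C@H](O[C@@H]2O[C@H](CO)[C@@H](O)[C@H](O)[C@H]2O)OC=C(C(=O)OC)[C@H]1CC(=O)OCc1ccccc1`, gives only > 15000 nM, which is a limit of the assay rather than a measured number. The position of compound 1 is therefore set by the limit of > 15000 nM in this assay, at which 2 of the 3 values shown sit, and no number places it relative to the others. Compound 2, with the structure `C/C=C1/[C@H](O[C@@H]2O[C@H](COC(C)=O)[C@@H](OC(C)=O)[C@H](OC(C)=O)[C@H]2OC(C)=O)OC=C(C(=O)OC)[C@H]1CC(=O)OCC`, likewise stops at a limit of the assay with > 15000 nM. Going by the values given here, the only compound with an actual number is compound 3, with the structure `C/C=C1/[C@H](O[C@@H]2O[C@H](COC(C)=O)[C@@H](OC(C)=O)[C@H](OC(C)=O)[C@H]2OC(C)=O)OC=C(C(=O)OC)[C@H]1CC(=O)OCCCCCCCCCCCCCCC`, which in this assay gives 3810 nM. Since two of the three values are limits, no change between measured compounds can be followed from one value to the next.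

The unmeasured compound 4 has the structure `C/C=C1/[C@H](O[C@@H]2O[C@H](CO)[C@@H](O)[C@H](O)[C@H]2O)OC=C(C(=O)OC)[C@H]1CC(=O)OCCc1ccc([N+](=O)[O-])cc1`. It differs from compound 1 in a single place: 4-nitrobenzyl in place of phenyl on a saturated chain carbon bound to an oxygen next to a carbonyl group. Among the compounds with values here, nothing among the measured compounds shows what this particular change does, so the expectation rests on compound 1 alone, whose value > 15000 nM is a limit. The step expected from this change is a number no higher from compound 1 to compound 4 (the limit leaves the size open), that is, no movement beyond the usual scatter. Compound 4 is accordingly expected to come out near 15000 nM, within a range from 5000 nM to 45000 nM, and may again be reported only as a limit of the assay.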

Compound 4, half-maximal inhibitory concentration: > 20000 nM
Compound 4: no number, only a limit (the forecaster's own chance of this, stated with the estimate: 60%); at least 1.3-fold (0.12 log units) between middle value and limit.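

In this assay compound 1 gives > 15000 nM, which is a limit of the assay. Compound 4 gives > 20000 nM, also a limit of the assay, and the size of the step between these two compounds cannot be read. The compounds shown leave open whether changing benzyl to 2-(4-nitrophenyl)ethyl alters antiproliferative activity at all.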